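The source may report more compounds than this note shows. Statements on the series, on what has been measured and on what is new or still open speak of the compounds shown alone.

Two compounds with a shared core carrying a bromoacetamide-type group have been measured in a functional assay on CCRF-CEM cells (Homo sapiens) for antiproliferative activity, read by MTT assay, with a stated time of 72 h; on this read-out higher numbers stand for weaker inhibition and lower numbers for stronger inhibition. Compound 1 `CC(Br)C(=O)Nc1cccc(C(=O)NC(N)=O)c1` gives 1470 nM. Compound 2 `NC(=O)NC(=O)c1cccc(NC(=O)CBr)c1` gives 725 nM. Going by the values given here, the single measured step, a 2.0-fold lower number from compound 1 to compound 2 (0.31 log units; beyond the scatter), is the only guide so far. On these two numbers compound 2 stands lowest, with compound 1 as its nearest neighbour at a higher number beyond the scatter.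

Compound 3 `O=C(CBr)Nc1cccc(C(=O)NC(=O)Nc2ccccc2)c1` is not yet measured. It differs from compound 2 by phenyl in place of hydrogen on an amide-type nitrogen. Among the compounds with values here, no measured step touches this end of the molecule: the step from compound 1 to compound 2 concerns the saturated chain carbon bound to the bromine atom, far from the amide-type nitrogen changed here, so it says nothing about the size or direction of the present change. The expectation therefore rests on compound 2 alone, with a wide allowance in either direction. Compound 3 is estimated to give 650 nM, with a range from 150 nM to 2800 nM. That estimate amounts to an expected 1.1-fold lower number from compound 2 to compound 3 (0.05 log units; within the scatter), well inside what the scatter permits.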

Compound 3, half-maximal inhibitory concentration: 5010 nM
Beside the measured number, compound 3's estimate is 7.7-fold (0.89 log units) below it, and the stated range ends below it.
By their numbers in this assay, from the lowest: compound 2; then compound 1; then compound 3.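

The amide-type nitrogen at this end of the molecule, untouched by the earlier step, matters in this assay: phenyl in place of hydrogen there gives a 6.9-fold higher number from compound 2 to compound 3 (0.84 log units; beyond the scatter). The change at the saturated chain carbon gave a 2.0-fold lower number from compound 1 to compound 2 (0.31 log units; beyond the scatter), so at both places that have been varied, the compound with hydrogen has the lower number, and compound 2, with hydrogen at both, stands lowest of the three. Nothing available explains why phenyl at this nitrogen goes with a higher number.

One replacement at one nitrogen cannot show whether this rise belongs to phenyl in particular or would also come with other groups there, such as methyl or cyclohexyl, and those two would help to separate the cases. Going by these compounds, it also remains open whether phenyl at this nitrogen would give a step of similar size and direction on a compound that carries the methyl of compound 1 on the saturated chain carbon.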